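Aryl Swap on a Thiourea in a Weak Antiproliferative Set

This account rests on a few compounds, and the source may have more. Where it says the series, first, only, none or still open, it means among the compounds named here.

In a functional assay on HeLa cells (Homo sapiens) for antiproliferative activity, with a stated time of 24 h (on this read-out higher numbers stand for weaker inhibition and lower numbers for stronger inhibition), compound 1 `Cc1ccccc1CN1CCc2c(sc(NC(=O)c3ccccc3Cl)c2C(N)=O)C1` sits at the limit of the measurement, giving > 50000 nM. Compound 2 `NC(=O)c1c(NC(=O)c2ccc(C(F)(F)F)cc2)sc2c1CCN(Cc1ccccc1F)C2` likewise reaches only a limit, giving > 50000 nM. Among the compounds with values here, compound 3 `NC(=O)c1c(NC(=O)c2ccccc2Cl)sc2c1CCN(C(=S)Nc1cccc3ccccc13)C2` is the one member that yields a number, giving 30800 nM in this assay, so it stands apart from the other two, which share (the limit of > 50000 nM in this assay, at which 2 of the 3 values shown sit). Compound 4 `NC(=O)c1c(NC(=O)c2ccccc2Cl)sc2c1CCN(C(=S)Nc1ccc(C(F)(F)F)cc1)C2` carries 4-(trifluoromethyl)phenyl in place of naphthalen-1-yl on an amide-type nitrogen. Within the data shown here, no measured pair differs in only this place, so there is no step to lean on. The swap is expected to move this assay at most modestly, toward weaker inhibition or not beyond the scatter, so compound 4 is estimated at 40000 nM (range 15000 nM to 100000 nM), an expected step of a 1.3-fold higher number from compound 3 to compound 4 (0.11 log units; within the scatter).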

Compound 4, half-maximal inhibitory concentration: > 50000 nM
Compound 4 ended at the assay's limit; the forecaster's own chance of this, stated with the estimate: 45%; at least 1.2-fold (0.09 log units) between middle value and limit.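

In this assay, within the data shown here, 4-(trifluoromethyl)phenyl in place of naphthalen-1-yl on an amide-type nitrogen gives the first step at this position: an at least 1.6-fold higher number from compound 3 to compound 4 (0.21 log units; that floor lies within the scatter). Going by these compounds, compound 4 gives only a limit, not a number, so this step is a floor and its true size is unknown. Compound 3 remains the only member with a number, and the rest of the set now gathers at one value: the limit of > 50000 nM in this assay, at which 3 of the 4 values shown sit.

On these data alone, whether the naphthalen-1-yl group truly favours inhibition stays open. So does how a plain phenyl or a cyclohexyl group on this nitrogen would read in this assay.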